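The source may report more compounds than this note shows. Statements on the series, on what has been measured and on what is new or still open speak of the compounds shown alone.

Of the compounds shown here, three with a shared core have been measured in a functional assay on WM 266-4 cells (Homo sapiens) for antiproliferative activity, read by MTT assay, with a stated time of 48 h; on this read-out lower numbers stand for stronger inhibition and higher numbers for weaker inhibition. There, compound 1 (`Cc1ccc(-c2cc(NC(=O)c3ccc(Br)nc3)n[nH]2)cc1`) gives 6780 nM, compound 2 (`O=C(Nc1cc(-c2ccc(Br)cc2)[nH]n1)c1cccnc1F`) gives 4680 nM and compound 3 (`O=C(Nc1cc(-c2ccc(Br)cc2)[nH]n1)c1cncc(Br)c1`) gives 8230 nM. The number for compound 3 lies within the usual scatter of both others, closest to that of compound 1, so these data set no order among them.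

The next compound is compound 4 (`O=C(Nc1cc(-c2ccc(Br)cc2)[nH]n1)c1ccc(Br)nc1`), with 6-bromopyridin-3-yl in place of 5-bromopyridin-3-yl on a carbonyl carbon. The two compounds have the same atoms, joined differently.

Within the data shown here, only one measured step bears directly on this kind of change. It is a 1.8-fold higher number from compound 2 to compound 3 (0.25 log units; within the scatter), a swap at the same carbonyl carbon, and it stays within the scatter. Compound 1 also carries the 6-bromopyridin-3-yl group, though it differs from compound 4 elsewhere. Compound 1 gives 6780 nM, which is within the scatter of compound 3. With so few compounds this evidence is thin, but it gives no reason to expect a step beyond the scatter in either direction in this assay.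

The expected change is a 1.3-fold lower number from compound 3 to compound 4 (0.10 log units; within the scatter), which is no real change beyond the scatter. For compound 4 the estimated value is 6500 nM, with an expected range from 3500 nM to 12000 nM.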

Compound 4, half-maximal inhibitory concentration: 8560 nM
Estimate against measurement, compound 4: 1.3-fold (0.12 log units) below, within the range that was stated.
By their numbers in this assay, from the lowest: compounds 2, 1, 3 and 4 (each within the scatter of the next).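

Exchanging 5-bromopyridin-3-yl for 6-bromopyridin-3-yl on the carbonyl carbon keeps the same atoms but joins them differently, and in this assay this gives a 1.0-fold higher number from compound 3 to compound 4 (0.02 log units; within the scatter), so this rearrangement produces no real change. The two other new comparisons also stay within the scatter: 6-bromopyridin-3-yl in place of 2-fluoropyridin-3-yl at the same carbonyl carbon gives a 1.8-fold higher number from compound 2 to compound 4 (0.26 log units; within the scatter), and bromo in place of methyl on an aromatic carbon gives a 1.3-fold higher number from compound 1 to compound 4 (0.10 log units; within the scatter). No measurement shown here offers an explanation for this flat picture.

Every group shown on the carbonyl carbon is a pyridin-3-yl ring carrying a halogen, so it remains open whether a pyridine ring bearing an amine or a carboxylic acid would move the number beyond the scatter in this assay. On the aromatic carbon that holds bromo or methyl, only those two groups appear, and a methoxy group or a longer chain there could show whether that place responds to a larger change.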